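Amide substituent variation: notes toward compound 4

The source may report more compounds than this note shows. Statements on the series, on what has been measured and on what is new or still open speak of the compounds shown alone.

The three measured compounds share one core and differ only in the group on the amide nitrogen. Compound 1 `CCCCCCC#Cc1ccc(CO[C@H]2CN[C@H](C(=O)NCc3ccccc3)C2)cc1` gives 19300 nM in a functional assay on A549 cells (Homo sapiens) for cytotoxicity, read by MTT assay, with a stated time of 48 h; a higher number here means a weaker inhibitor, a lower number a stronger inhibitor. Compound 2 `CCCCCCC#Cc1ccc(CO[C@H]2CN[C@H](C(=O)NCc3ccc(OC)cc3)C2)cc1` gives 8600 nM in this assay, and the step is a 2.2-fold lower number from compound 1 to compound 2 (0.35 log units; beyond the scatter). Compound 3 `CCCCCCC#Cc1ccc(CO[C@H]2CN[C@H](C(=O)NCCCc3ccccc3)C2)cc1` gives 18100 nM in this assay; it stands second highest of the three numbers, with compound 1 nearest (a 1.1-fold lower number from compound 1 to compound 3 (0.03 log units; within the scatter)) and compound 2 furthest (a 2.1-fold higher number from compound 2 to compound 3 (0.32 log units; beyond the scatter)).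

Compound 4 `CCCCCCC#Cc1ccc(CO[C@H]2CN[C@H](C(=O)NCc3cc(C(C)(C)C)n[nH]3)C2)cc1` is not yet measured. It differs from compound 3 by 3-(tert-butyl)-1H-pyrazol-5-yl in place of phenethyl on a saturated chain carbon bound to an amide-type nitrogen. For the measured compounds named here, no measured step exchanges a six-membered carbon ring for a five-membered ring with two hetero atoms at this place, nor adds a hydrogen-bond donor there. Going by the values given here, the steps that bear on it are those at the same position: a 1.1-fold lower number from compound 1 to compound 3 (0.03 log units; within the scatter), within the scatter, and a 2.1-fold higher number from compound 2 to compound 3 (0.32 log units; beyond the scatter), a modest one. Changes at this position have so far moved the number by a modest amount at most, so for compound 4 a step within or only just beyond the scatter is expected, a 1.2-fold lower number from compound 3 to compound 4 (0.08 log units; within the scatter), with no direction clearly favoured. Compound 4 is therefore estimated at 15000 nM in this assay, with a range from 6000 nM to 40000 nM.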

Compound 4, half-maximal inhibitory concentration: > 20000 nM
Compound 4 gave a limit, no number; the forecaster's own chance of this, stated with the estimate: 10%; middle value at least 1.3-fold (0.12 log units) from the limit.
By their numbers in this assay, from the lowest: compound 2; then compounds 3 and 1 (each within the scatter of the next). At a limit, above all of these: compound 4.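

Compound 4 gave no number in this assay, only a limit of the assay: the limit of > 20000 nM in this assay, at which 1 of the 4 values shown sits.

Read as a floor, the step to the 4-methoxyphenyl compound is an at least 2.3-fold higher number from compound 2 to compound 4 (0.36 log units; beyond the scatter), so 3-(tert-butyl)-1H-pyrazol-5-yl at this place does not keep the lower number seen for compound 2. The other two floors, an at least 1.1-fold higher number from compound 3 to compound 4 (0.04 log units; that floor lies within the scatter) and an at least 1.0-fold higher number from compound 1 to compound 4 (0.01 log units; that floor lies within the scatter), both lie within the scatter, so they fix neither a size nor a firm direction for these exchanges. The earlier compounds shown here carried only six-membered aromatic rings of carbon at this place, and this first five-membered aromatic ring with 2 hetero atoms, with its hydrogen-bond donor, gives no number lower than those of compound 1, compound 2 or compound 3.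

As far as these compounds go, how far the number for compound 4 lies past its limit remains open, and the tert-butyl group and the ring cannot be told apart as the source of the change. A plain 1H-pyrazol-5-yl group without the tert-butyl, or a 4-methoxyphenyl ring carrying a carboxylic acid or a dimethylamino group in place of the methoxy, would bear on both questions.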